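The source may hold more compounds than are shown below. What is called first, only, known or untested is meant among the compounds shown, and "the series" means these compounds.

Compound 1 `CC(C)Cc1ccc(NS(=O)(=O)c2ccc(N3CCNC3=O)cc2)cc1` is the starting point of this step. In a functional assay on MCF7 cells (Homo sapiens) for antiproliferative activity, read by sulforhodamine B assay, with a stated time of 48 h (a higher number here means a weaker inhibitor, a lower number a stronger inhibitor), compound 1 returns only a limit, > 1000 nM, and no number. Compound 1 therefore stands at the limit of > 1000 nM in this assay, at which 1 of the 2 values shown sits. Compound 2 `Cc1ccc(NS(=O)(=O)c2ccc(N3CCNC3=O)cc2)c(C)c1`, the other measured member of the series, gives 230 nM in this assay. Compound 3 `Cc1ccc(NS(=O)(=O)c2ccc(N3CCNC3=O)cc2)cc1` awaits measurement. The change from compound 1 to compound 3 is hydrogen in place of isopropyl on a saturated chain carbon bound to an aromatic carbon. Among the compounds with values here, no measured step covers this change. In this assay the step is expected to run toward stronger inhibition, beyond the scatter, as an at least 2.0-fold lower number from compound 1 to compound 3 (0.30 log units; that floor lies within the scatter). Compound 3 is expected at 500 nM, within 150 nM to 2000 nM.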

Compound 3, half-maximal inhibitory concentration: 610 nM
For compound 3 the middle estimate is 1.2-fold (0.09 log units) below the measured one, and the stated range covers the measured number.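

In this assay, hydrogen in place of isopropyl on a saturated chain carbon bound to an aromatic carbon gives an at least 1.6-fold lower number from compound 1 to compound 3 (0.21 log units; that floor lies within the scatter), so the isobutyl to methyl change has only a floor for its size, and that floor does not clear the scatter. Compound 1 remains a limit and not a number: the limit of > 1000 nM in this assay, at which 1 of the 3 values shown sits. The methyl on an aromatic carbon does show a step, as hydrogen in its place gives a 2.7-fold higher number from compound 2 to compound 3 (0.42 log units; beyond the scatter). Open, on these data alone, is how an ethyl or propyl chain at the saturated position would compare with compound 3, and whether an amine or a carboxylic acid on that aromatic carbon would differ from compound 3.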